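Carboxymethyl in place of carboxy on compound 1

The source may hold more compounds than are shown below. What is called first, only, known or untested is meant among the compounds shown, and "the series" means these compounds.

Measured so far in a functional assay on the whole organism (strain Hartley) for inhibition, with Cavia porcellus as the target, with stated times of 15 min and 2 min; on this read-out lower numbers stand for an effect already at smaller amounts and higher numbers for an effect only at larger amounts of compound:
- compound 1 `CCCCC1([C@H](O)/C=C/C2CCC(=O)[C@@H]2CCCCCC(=O)O)CCC1`: 0.32 mg/kg
- compound 2 `CCCCC1([C@@H](O)/C=C/C2CCC(=O)[C@@H]2CCCCCCC(=O)OCC)CCC1`: 0.00206 mg/kg
- compound 3 `CCCCC1([C@H](O)/C=C/C2[C@H](O)CC(=O)[C@@H]2C/C=C\CCCC(=O)O)CCC1`: 0.00106 mg/kg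

Compound 1 has the highest number of the three, and its gaps to compound 2 and compound 3 both lie well beyond the scatter. Those two sit within the scatter of each other.

Next in line is compound 4 `CCCCC1([C@H](O)/C=C/C2CCC(=O)[C@@H]2CCCCCCC(=O)O)CCC1`, which carries carboxymethyl in place of carboxy on a saturated chain carbon, five bonds along the chain from a saturated ring carbon.

Going by the values given here, no measured pair differs in one place only, so this step has no direct precedent. The expectation is a large move to a lower number in this assay, beyond the scatter, resting on how far compound 1 at 0.32 mg/kg lies from compound 2 at 0.00206 mg/kg. The expected change is a 53-fold lower number from compound 1 to compound 4 (1.73 log units; beyond the scatter). The estimate for compound 4 is 0.006 mg/kg, with an expected range of 0.001 mg/kg to 0.04 mg/kg.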

Compound 4, dose for half-maximal effect: 47.8 mg/kg
Compound 4: middle estimate off by 8000-fold (3.90 log units), on the low side; measured number outside the range, above it.
By their numbers in this assay, from the lowest: compounds 3 and 2 (each within the scatter of the next); then compound 1; then compound 4.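

In this assay, carboxymethyl in place of carboxy on a saturated chain carbon, five bonds along the chain from a saturated ring carbon, brings a 150-fold higher number from compound 1 to compound 4 (2.17 log units; beyond the scatter). Going by these compounds alone, this is the first comparison in which only one place differs, and it shows that this position is sensitive to the change: a single added chain carbon, with the carboxy end kept, moves the number far beyond the scatter, and towards larger amounts of compound. Nothing at hand accounts for the size of this step.

Going by these compounds, the direction of the step on the shorter side stays open, since a shorter chain ending in a carboxylic acid would test whether the chain of compound 1 is itself the best length. Also open, on these data alone, is how an ethyl ester at the chain end of compound 4, with all else unchanged, would read.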